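The source may hold more compounds than are shown below. What is called first, only, known or untested is meant among the compounds shown, and "the series" means these compounds.

Two small compounds open the set. Compound 1 `C#CCn1c(=O)c(C=O)cc2cc(OC)ccc21` and compound 2 `C#CCn1c(=O)c(C=O)cc2cc(C)ccc21` share a core and differ by methyl in place of methoxy on an aromatic carbon. In a functional assay on SK-OV-3 cells (Homo sapiens) for cytotoxicity, read by MTT assay, with a stated time of 24 h (a higher number here means a weaker inhibitor, a lower number a stronger inhibitor), compound 1 gives > 100000 nM, which is a limit of the assay, not a number. Compound 2 gives > 100000 nM in this assay, again a limit rather than a number. Between them lies a step that the two limits leave unreadable from compound 1 to compound 2, because the limit of > 100000 nM in this assay, at which 2 of the 3 values shown sit, hides whatever difference the change may have made.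

Compound 3 `C#CCn1c(=O)c(/C=C/C(=O)/C=C(O)/C=C/c2ccc(O)c(OC)c2)cc2cc(OC)ccc21` carries a much larger side chain; the difference between its core and that of compound 1 is not broken down here. In this assay, for the measured compounds named here, compound 3 gives 14000 nM, the only measured number in the set.

Compound 4 `C#CCn1c(=O)c(/C=C/C(=O)/C=C(O)/C=C/c2ccc(O)c(OC)c2)cc2cc(C)ccc21` is not yet measured. It differs from compound 3 by methyl in place of methoxy on an aromatic carbon, the same change as that from compound 1 to compound 2. Since that earlier step is unreadable, the expectation rests on compound 3 alone, with 14000 nM as the anchor. The expected step is a 1.1-fold higher number from compound 3 to compound 4 (0.03 log units; within the scatter), within the usual scatter. Compound 4 is therefore estimated at 15000 nM, with a range from 5000 nM to 45000 nM.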

Compound 4, half-maximal inhibitory concentration: 12800 nM
For compound 4 the middle estimate is 1.2-fold (0.07 log units) above the measured one; measured number inside the range.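

In this assay putting methyl in place of methoxy on the larger compounds gives a 1.1-fold lower number from compound 3 to compound 4 (0.04 log units; within the scatter) and so leaves the reading within the usual scatter. This is a single readable step on a single core: it shows that on the core of compound 3 the two groups give readings that cannot be told apart here, but not that the change would behave the same way on any other core. For the compounds shown here, the same change on the smaller core gives no second step to set beside it, because compound 1 and compound 2 both stand at a limit of the assay rather than at a number: the limit of > 100000 nM in this assay, at which 2 of the 4 values shown sit.

The compounds shown carry only methoxy or methyl at this aromatic carbon, so how an amine, a carboxylic acid or a longer chain such as ethoxy would read there stays open. Also open, going by these compounds, is whether the match between methoxy and methyl would hold on a third core or in other cells.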